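This account rests on a few compounds, and the source may have more. Where it says the series, first, only, none or still open, it means among the compounds named here.

Measured so far in a functional assay on HepG2 cells (Homo sapiens) for cytotoxicity, read by MTT assay, with a stated time of 24 h; a higher number here means a weaker inhibitor, a lower number a stronger inhibitor:
- compound 1 `COc1cc(/C=C2\CN(S(=O)(=O)c3ccc(F)cc3)C/C(=C\c3ccccc3F)C2=O)cc(OC)c1OC`: 7940 nM
- compound 2 `COc1cc(/C=C2\CN(S(=O)(=O)c3ccc(F)cc3)C/C(=C\c3cc(OC)c(OC)c(OC)c3)C2=O)cc(OC)c1`: 3890 nM

Of these two numbers, the lower belongs to compound 2, at 3890 nM, making it the stronger inhibitor of the pair.

The next molecule, compound 3 `COc1cc(/C=C2\CN(S(=O)(=O)c3ccc(NC(C)=O)cc3)C/C(=C\c3cc(OC)c(OC)c(OC)c3)C2=O)cc(OC)c1`, keeps all of compound 2 except for one group: acetamido in place of fluoro on an aromatic carbon. In other words, 4-fluorophenyl becomes 4-acetamidophenyl, with acetamido in place of fluoro on an aromatic carbon.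

For the measured compounds named here, no measured step involves this group. The only one available, a 2.0-fold lower number from compound 1 to compound 2 (0.31 log units; beyond the scatter), is a modest step from a change elsewhere in the molecule. It gives a rough idea of what one swap can do in this series, but it says nothing about direction here. With no basis for choosing a direction, no step beyond the scatter is expected in this assay, although the uncertainty is wide. The expected change is a 1.0-fold higher number from compound 2 to compound 3 (0.01 log units; within the scatter). Compound 3 is estimated at about 4000 nM, with an expected range of 1500 nM to 11000 nM.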

Compound 3, half-maximal inhibitory concentration: 4140 nM
Compound 3: middle estimate off by 1.0-fold (0.01 log units), on the low side; the range from low to high includes it.
By their numbers in this assay, from the lowest: compounds 2, 3 and 1 (each within the scatter of the next, the first and the last beyond it).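

In this assay, putting acetamido in place of fluoro on this aromatic carbon gives a 1.1-fold higher number from compound 2 to compound 3 (0.03 log units; within the scatter), so the two compounds cannot be told apart in this measurement. For the compounds shown here, this is the first look at this position, para to a large group: the earlier step concerned a different part of the molecule, whereas here the group grows from 1 heavy atom to 4 and gains a hydrogen-bond donor and a hydrogen-bond acceptor, with no step beyond the scatter. No measured evidence is available that would explain this outcome.

Going by these compounds, a single swap cannot show how much change this position accepts, so it remains open whether an amine or a carboxylic acid on this aromatic carbon, or a longer chain in place of the acetamido methyl, would shift the number beyond the scatter. On these data alone, it is also open whether 4-acetamidophenyl would give the same result with the 2-fluorophenyl group of compound 1 on the other side of the shared core.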